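Acetyl swap on the aryl group of compound 2

The compounds below may be only part of what the source reports. "The series", "measured", "known", "first", "only" and "open" are said of these compounds alone.

Measured so far:
- compound 1 `COc1cc(-c2ccnc3cc(-c4ccccc4)nn23)cc(OC)c1OC`: 3880 nM
- compound 2 `COc1cc(-c2ccnc3cc(-c4cccc(C)c4)nn23)cc(OC)c1OC`: 6150 nM

Both values come from a functional assay on HCT-116 cells (Homo sapiens) for inhibition, read by CCK-8 assay, with a stated time of 48 h; a lower number here means a stronger inhibitor, a higher number a weaker inhibitor. Among the compounds with values here, compound 2 is not separated from compound 1: the single measured step is a 1.6-fold higher number from compound 1 to compound 2 (0.20 log units; within the scatter).

The next compound is compound 3 `COc1cc(-c2ccnc3cc(-c4ccc(C(C)=O)cc4)nn23)cc(OC)c1OC`. Its change from compound 2 is 4-acetylphenyl in place of 3-methylphenyl on an aromatic carbon of the five-membered aromatic ring with 2 nitrogen. Within the data shown here, the only measured evidence is the methyl in place of hydrogen on an aromatic carbon of that same aryl group, and that step stayed within the scatter. Among the measured compounds shown here, it is a small change, and no measured compound carries an acetyl group, so the data give no direction for the new substituent. No step beyond the scatter is therefore expected in this assay, and the expectation stays anchored on compound 2 at 6150 nM. With a single step to go on, the range is kept wide.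

The expected step is a 1.2-fold lower number from compound 2 to compound 3 (0.09 log units; within the scatter). For compound 3 the estimated value is 5000 nM, with an estimated range of 1700 nM to 15000 nM.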

Compound 3, half-maximal inhibitory concentration: 4390 nM
Compound 3: the middle estimate sits 1.1-fold (0.06 log units) above what was measured; the range from low to high includes it.
By their numbers in this assay, from the lowest: compounds 1, 3 and 2 (each within the scatter of the next).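

Working notes on the aryl group: in this assay the 4-acetylphenyl brings a carbonyl and a hydrogen-bond acceptor to an aryl group that carried no acceptor in the earlier compounds, yet the number remains within the scatter of both neighbours (a 1.4-fold lower number from compound 2 to compound 3 (0.15 log units; within the scatter); a 1.1-fold higher number from compound 1 to compound 3 (0.05 log units; within the scatter)). The second of these steps is the cleaner reading of the acetyl group, as it compares the substituted ring with the plain phenyl of compound 1, whereas the step from compound 2 swaps both the substituent and its place on the ring. Compounds 1, 2 and 3 therefore show that a small alkyl group and a larger carbonyl-bearing group on this aryl ring are not separated in this cell read-out, and nothing available explains that flatness.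

Still open, from the compounds shown here alone, is whether any group on this aryl ring moves the number beyond the scatter, for example a basic amine, a carboxylic acid or a longer chain ending in a hydroxyl group. Also open, going by these compounds, is the role of ring position alone, which a pair such as 3-acetylphenyl and 4-acetylphenyl would isolate.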